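A new group on the shared core of compound 2

The source may report more compounds than this note shows. Statements on the series, on what has been measured and on what is new or still open speak of the compounds shown alone.

Compound 1 `COc1ccc(CN(C(=O)Cn2cc(CSc3nc4ccccc4s3)nn2)c2cc(OC)c(OC)c(OC)c2)cc1` and compound 2 `COc1ccc(CN(C(=O)Cn2cc(CSC3=NCCS3)nn2)c2cc(OC)c(OC)c(OC)c2)cc1` share one core and differ only in the group on a sulfur. In a functional assay on HepG2 cells (Homo sapiens) for antiproliferative activity, read by MTT assay, with a stated time of 48 h (a lower number here means a stronger inhibitor, a higher number a weaker inhibitor), compound 1 gives 49200 nM and compound 2 gives 25000 nM on the same read-out. These two numbers lie within the scatter of each other, so compound 2 stands level with compound 1. Compound 3 `COc1ccc(CN(C(=O)Cn2cc(CNS(=O)(=O)c3ccc(Br)cc3)nn2)c2cc(OC)c(OC)c(OC)c2)cc1` brings a larger change, namely a group of 11 heavy atoms (6 carbon, 1 nitrogen, 2 oxygen, 1 sulfur, 1 bromine; one six-membered aromatic ring of carbon only) in place of a group of 6 heavy atoms (3 carbon, 1 nitrogen, 2 sulfur; one five-membered non-aromatic ring with 2 hetero atoms), on a saturated chain carbon bound to an aromatic carbon as the whole difference. The entering ((4-bromophenyl)sulfonyl)amino sits on a saturated chain carbon bound to an aromatic carbon, and the sulfur of compound 2 leaves with the old group. Among the compounds with values here, the only measured step is a 2.0-fold lower number from compound 1 to compound 2 (0.29 log units; within the scatter) and it is a loose guide, as it kept that sulfur. With that step alone, no shift beyond the scatter is expected in this assay here. The expected change is a 1.3-fold lower number from compound 2 to compound 3 (0.10 log units; within the scatter) as estimated. For compound 3 the estimated value is 20000 nM with an expected range from 5000 nM to 60000 nM as its bounds.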

Compound 3, half-maximal inhibitory concentration: 7370 nM
Estimate against measurement, compound 3: 2.7-fold (0.43 log units) above, and the stated range covers the measured number.
By their numbers in this assay, from the lowest: compound 3; then compounds 2 and 1 (each within the scatter of the next).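

In this assay, the saturated chain carbon bound to an aromatic carbon now shows a change beyond the scatter, which the earlier pair, differing only in the group on a sulfur, did not show. Placing ((4-bromophenyl)sulfonyl)amino on this carbon gives a 3.4-fold lower number from compound 2 to compound 3 (0.53 log units; beyond the scatter) and also a 6.7-fold lower number from compound 1 to compound 3 (0.82 log units; beyond the scatter) in the same assay. Compound 3 is therefore the strongest of the three, with both sulfur-linked groups, which stand level with each other, giving way to the new group. No measurement at hand bears on why this step occurs.

From the compounds shown here alone, the bromine, the sulfonyl and the aromatic ring all enter together, so their separate shares remain open. A plain amine on the same carbon, or chlorine in place of the bromine, would begin to separate them.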